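This account rests on a few compounds, and the source may have more. Where it says the series, first, only, none or still open, it means among the compounds named here.

Measured compounds in an ADME assay on Raji cells (Homo sapiens) for cytotoxicity, with a stated time of 72 h; on this read-out lower numbers stand for an effect already at smaller amounts and higher numbers for an effect only at larger amounts of compound:
- compound 1 `Cc1cc(NC(=O)Nc2cc(F)ccc2F)c2ccccc2n1`: > 25000 nM
- compound 2 `Cc1cc(NC(=O)Nc2ccccc2F)c2ccccc2n1`: > 25000 nM

Compound 1 gives only the limit > 25000 nM in this assay. Compound 2 likewise gives only the limit > 25000 nM in this assay. Going by the values given here, the single measured step, a step that the two limits leave unreadable from compound 1 to compound 2, is therefore unreadable, both values sitting at the limit of > 25000 nM in this assay, at which 2 of the 2 values shown sit.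

Compound 3 `Cc1cc(NC(=O)Nc2ccc(F)cc2F)c2ccccc2n1` differs from compound 2 by fluoro in place of hydrogen on an aromatic carbon. No readable step bears on this change. With compound 2 at a limit, the expected step that the limit leaves unreadable from compound 2 to compound 3 is a limit-to-limit one and most likely not beyond the scatter. For compound 3 the estimate in this assay is 40000 nM, expected to fall between 15000 nM and 150000 nM.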

Compound 3, half-maximal effective concentration: > 25000 nM
Compound 3: no number, only a limit; the forecaster's own chance of this, stated with the estimate: 85%; the middle value lies beyond the limit too.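

No step from compound 2 to compound 3 can be read, both values being limits: the limit of > 25000 nM in this assay, at which 3 of the 3 values shown sit.

From the compounds shown here alone, whether compound 1, compound 2 and compound 3 differ at all in cytotoxicity remains open, as does which change would give a readable value.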